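Dialkylamino in place of amino on the shared core

The source may report more compounds than this note shows. Statements on the series, on what has been measured and on what is new or still open speak of the compounds shown alone.

Two compounds of this series have been run in a functional assay on the whole organism for antagonist activity, with Rattus norvegicus as the target; on this read-out lower numbers stand for an effect already at smaller amounts and higher numbers for an effect only at larger amounts of compound. Compound 1 `CN(C)c1ncnc2c1ncn2C1CC1` gives 9 mg/kg. Among the measured compounds shown here, compound 2 `Nc1ncnc2c1ncn2CC1CC1` gives 20 mg/kg, the highest of the two numbers; the gap to compound 1 lies beyond the scatter, though the two structures differ in more than one place and no single step links them. Compound 3 `CCN(c1ncnc2c1ncn2CC1CC1)C1CC1` has not yet been measured in this assay. It differs from compound 2 by cyclopropyl(ethyl)amino in place of amino on an aromatic carbon. With no measured pair that isolates this change, the expectation rests only on the two numbers shown: the one compound bearing a dialkylamino group at this position, compound 1, gives 9 mg/kg, the lower of the two. A modest move toward lower doses is therefore expected, not a large one. Compound 3 is expected to come in near 10 mg/kg. For compound 3 the expected range runs from 4 mg/kg to 30 mg/kg. The expected step in this assay is a 2.0-fold lower number from compound 2 to compound 3 (0.30 log units; within the scatter), toward lower doses.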

Compound 3, dose for half-maximal effect: 20 mg/kg
The estimate for compound 3 lay 2.0-fold (0.30 log units) below the measured number; the measured number falls inside the stated range.
By their numbers in this assay, from the lowest: compound 1; then compounds 2 and 3 (each within the scatter of the next).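

In this assay, replacing amino with cyclopropyl(ethyl)amino on this aromatic carbon gives no change at the digits printed from compound 2 to compound 3 (within the scatter). Among the compounds shown here, this is the first single-place step, and it shows that the position accepts a group of 6 heavy atoms, including a three-membered ring and with 0 hydrogen-bond donors, in place of amino without a shift that can be read on this read-out. The amino hydrogens therefore do not appear to be needed for activity in this whole-organism assay, at least in this pair, and nothing at hand accounts for the flat step.

For the compounds shown here, still open is whether other groups on this carbon, such as ethylamino, which has only one alkyl group on the nitrogen, or a morpholine ring, would also stay level with compound 2 or would move the dose away from it. Also open, from the compounds shown here alone, is how the cyclopropyl group directly on the ring nitrogen of compound 1 and the cyclopropylmethyl group of compound 2 compare when the group on this carbon is held the same, as compound 1 differs from compound 2 in more than one place.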